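Added methoxy on the aryl ring: expected cytotoxicity of compound 4

The source may report more compounds than this note shows. Statements on the series, on what has been measured and on what is new or still open speak of the compounds shown alone.

Compound 1 `COc1cc(NC(C)CCCNC(=O)/C=C/c2ccc(OC)c(OC)c2)c2ncccc2c1` and compound 2 `COc1cc(NC(C)CCCNC(=O)/C=C/c2cc(OC)c(OC)c(OC)c2)c2ncccc2c1` share one core; compound 3 `COc1ccc(/C=C/C(=O)NNC(=O)NCCCC(C)Nc2cc(OC)cc3cccnc23)cc1` and compound 4 `COc1cc(NC(C)CCCNC(=O)NNC(=O)/C=C/c2ccc(OC)c(OC)c2)c2ncccc2c1` share another, and the difference between the two cores is not broken down here. In an ADME assay on L6 cells (Rattus norvegicus) for cytotoxicity, read by resazurin assay, with a stated time of 70 h (on this read-out higher numbers stand for weaker inhibition and lower numbers for stronger inhibition), compound 1 gives only a limit, > 220000 nM. In this assay compound 2 also gives only a limit, > 210000 nM. The step that the two limits leave unreadable from compound 1 to compound 2 is thus unreadable, as both values sit at limits, the limit of > 210000 nM in this assay, at which 1 of the 3 values shown sits, and (the limit of > 220000 nM in this assay, at which 1 of the 3 values shown sits). In this assay, among the measured compounds shown here, compound 3 gives 3600 nM, the only number among the three.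

The change from compound 1 to compound 2, (methoxy in place of hydrogen on an aromatic carbon), is the same kind of change as that from compound 3 to compound 4, (methoxy in place of hydrogen on an aromatic carbon); around the place, the first is also meta to a methoxy group, the second is not. The measured pair gives no readable size for this change. The step of no change at the digits printed from compound 3 to compound 4 (within the scatter) is expected to lie within the usual scatter, resting on compound 3 at 3600 nM and on the measured pair giving no readable size for this change. The estimate for compound 4 is 3600 nM, between 1500 nM and 9000 nM.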

Compound 4, half-maximal inhibitory concentration: 37000 nM
For compound 4 the middle estimate is 10-fold (1.01 log units) below the measured one; measured number outside the range, above it.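

In this assay, methoxy in place of hydrogen on an aromatic carbon, 4-methoxyphenyl to 3,4-dimethoxyphenyl, gives a 10-fold higher number from compound 3 to compound 4 (1.01 log units; beyond the scatter), so on the core of compound 3 this change goes with weaker inhibition. Whether a step of this size or direction also holds on the core of compound 1 is not shown, as the step to compound 2 cannot be read and compound 2 gives a limit of the assay, not a number: the limit of > 210000 nM in this assay, at which 1 of the 4 values shown sits. Compound 1 also gives a limit, so the result rests on a single readable pair and no rule for carrying the change between cores follows: the limit of > 220000 nM in this assay, at which 1 of the 4 values shown sits.

The compounds shown leave open whether an amine or a carboxylic acid in place of the added methoxy on the same aryl ring would move the number in the same direction. They also leave open whether the step would persist on the core of compound 3 with a longer chain in the linker.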